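Three Level Compounds and One Untested Ester

This account rests on a few compounds, and the source may have more. Where it says the series, first, only, none or still open, it means among the compounds named here.

Compound 1 `COc1cc(OC)c2cc(-c3ccccc3)c(O)nc2c1`: 10000 nM
Compound 2 `COc1ccc(-c2cc3cccc(OC)c3nc2O)cc1`: 10000 nM
Compound 3 `CCN(CC)C(=O)Cn1c(=O)c(-c2ccc(OC)cc2)cc2c(OC)cc(OC)cc21`: 10000 nM

All three compounds were tested in a functional assay on A-427 cells (Homo sapiens) for cytotoxicity, read by colorimetric assay and MTT assay; a lower number here means a stronger inhibitor, a higher number a weaker inhibitor. There, compound 3 gives 10000 nM, which puts it level with compound 1 and compound 2, with no difference beyond the usual scatter of repeat measurements.

Compound 4 `COC(=O)CCn1c(=O)c(-c2ccc(OC)cc2)cc2c(OC)cc(OC)cc21` has not yet been measured. It differs from compound 3 in one place: (methoxycarbonyl)methyl in place of diethylcarbamoyl on a saturated chain carbon bound to an aromatic nitrogen. In words, (methoxycarbonyl)methyl stands in place of diethylcarbamoyl on a saturated chain carbon bound to an aromatic nitrogen. Read one bond further out, (diethylcarbamoyl)methyl becomes 2-(methoxycarbonyl)ethyl.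

Within the data shown here, no two measured compounds differ in just one place, so the data offer no direct guide to the size of this change. The only anchor is the level set by the three measured compounds, so no step beyond the scatter is expected in this assay, in either direction. The expected change is no change at the digits printed from compound 3 to compound 4 (within the scatter). Compound 4 is estimated at 10000 nM, with an expected range from 3000 nM to 20000 nM.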

Compound 4, half-maximal inhibitory concentration: 10000 nM
Beside the measured number, compound 4's estimate shows no gap at the digits printed, within the range that was stated.
By their numbers in this assay, from the lowest: compounds 1, 2, 3 and 4 (each within the scatter of the next).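

In this assay, placing (methoxycarbonyl)methyl where diethylcarbamoyl stood, on a saturated chain carbon bound to an aromatic nitrogen, gives no change at the digits printed from compound 3 to compound 4 (within the scatter). Among these compounds, this is the first direct reading of a single change at this position, and it shows that replacing a group of 7 heavy atoms with one of 5, and the group's nitrogen with a second oxygen, leaves the result within the scatter. No measurement shown here accounts for this result.

A single swap cannot show whether this position matters in general, or whether a carboxylic acid, a tertiary amine or a longer carbon chain at the same place would shift the value. Nor can it show whether any change to the shared core would yield a stronger inhibitor than these four compounds.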